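The compounds below may be only part of what the source reports. "The series", "measured", "known", "first", "only" and "open" are said of these compounds alone.

Compound 1 `CCOC(=O)N1CC[C@H](c2ccc(Cl)cc2)[C@H]1C(=O)N1CCN(c2ccc(C)cc2[C@@H](N)C(C)C)CC1` is tested in an assay on HEK293 cells for displacement of a labelled ligand from Melanocortin receptor 4 (Homo sapiens) (a lower number here means a stronger inhibitor, a higher number a weaker inhibitor), where compound 1 gives 42 nM. Among the compounds with a single number it stands lowest, and the nearest is compound 2 `Cc1ccc(N2CCN(C(=O)[C@@H]3[C@@H](c4ccc(Cl)cc4)CCN3C(=O)OC(C)C)CC2)c([C@@H](N)C(C)C)c1`, which in this assay gives 68 nM; that step, a 1.6-fold higher number from compound 1 to compound 2 (0.21 log units; within the scatter), is simply a methyl in place of a hydrogen on the saturated chain carbon bound to the oxygen next to the carbonyl group. Compound 3 `CCOC(=O)N1CC[C@H](c2ccc(Cl)cc2)[C@@H]1C(=O)N1CCN(c2ccc(C)cc2[C@@H](N)C(C)C)CC1` has several entries in this assay, 11 nM; 16 nM (2 entries), and the several entries of compound 3 in this assay, 11 nM; 16 nM (2 entries) shows how closely those repeats agree. Compound 3 is notable for (the fact that compounds 1 and 3 differ only in the configuration as drawn), and a comparison of its values with that of compound 1 shows that configuration on the shared core matters here.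

Compound 4 `CCOC(=O)N1CC[C@@H](c2ccc(Cl)cc2)[C@H]1C(=O)N1CCN(c2ccc(C)cc2[C@@H](N)C(C)C)CC1` is the step now followed: the two compounds have the same atoms and bonds and differ only in configuration as drawn: 1 of 3 stereo elements differ; a stereocentre at a saturated ring carbon is drawn R in compound 1 and S in compound 4. Among the compounds with values here, the only step of comparable kind is the one from compound 1 to compound 3, so a shift beyond the scatter in this assay is expected, but its direction cannot be read from the measured steps. Compound 4 is estimated at 100 nM, within 15 nM to 700 nM, an expected step of a 2.4-fold higher number from compound 1 to compound 4 (0.38 log units; beyond the scatter).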

Compound 4, inhibition constant: 130 nM
Compound 4: the middle estimate sits 1.3-fold (0.11 log units) below what was measured; measured number inside the range.
By their numbers in this assay, from the lowest: compounds 1, 2 and 4 (each within the scatter of the next, the first and the last beyond it).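

In this assay, redrawing one stereocentre at a saturated ring carbon, with no atom gained or lost, gives a 3.1-fold higher number from compound 1 to compound 4 (0.49 log units; beyond the scatter). This shift is modest, but unlike the earlier methyl change, a 1.6-fold higher number from compound 1 to compound 2 (0.21 log units; within the scatter), it lies beyond the scatter. Compound 3, at 11 nM; 16 nM (2 entries), had already pointed to configuration on the shared core, but it differs from compound 1 at a different stereocentre, so the new result shows that this second stereocentre also matters, with the number moving upward when it is drawn S: the fact that compounds 1 and 4 differ only in the configuration as drawn.

As far as these compounds go, whether the same change in configuration gives a similar step when a methoxy group replaces the chloro group on the aromatic ring stays open. The numbers also give no reason for the step, only its size and direction.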